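This account rests on a few compounds, and the source may have more. Where it says the series, first, only, none or still open, it means among the compounds named here.

Compound 1 `CCCCCc1ccc(NS(=O)(=O)c2ccc(N3CCNC3=O)cc2)cc1`: 990 nM
Compound 2 `COc1ccc(NS(=O)(=O)c2ccc(N3CCNC3=O)cc2)cc1`: 800 nM

Both compounds share one core and differ only in the group on the far aromatic ring. In a functional assay on HT-29 cells (Homo sapiens) for antiproliferative activity, read by sulforhodamine B assay, with a stated time of 48 h (a higher number here means a weaker inhibitor, a lower number a stronger inhibitor), compound 1 gives 990 nM, and in this assay compound 2 gives 800 nM. The step of a 1.2-fold lower number from compound 1 to compound 2 (0.09 log units; within the scatter) is the only one measured here, so compound 2 stands next to compound 1 with a gap that repeated measurements could easily produce on their own; neither can be called the more potent of the two.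

Compound 3 `O=C1NCCN1c1ccc(S(=O)(=O)Nc2ccc(F)c(F)c2)cc1` carries the change (3,4-difluorophenyl in place of 4-methoxyphenyl on a sulfonamide nitrogen). Going by the values given here, the sole measured step, a 1.2-fold lower number from compound 1 to compound 2 (0.09 log units; within the scatter), bears on it only loosely: it shows that swapping one group on this aromatic ring for another left the number essentially where it was. The step to compound 3 replaces the ring substitution more thoroughly, so the expectation rests on thin evidence. The estimated step of a 1.1-fold higher number from compound 2 to compound 3 (0.05 log units; within the scatter) is expected to stay within the scatter. Compound 3 is therefore estimated at 900 nM, within a range of 300 nM to 2700 nM.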

Compound 3, half-maximal inhibitory concentration: 350 nM
Compound 3: the middle estimate sits 2.6-fold (0.41 log units) above what was measured; low and high end bracket the measured number.
By their numbers in this assay, from the lowest: compound 3; then compounds 2 and 1 (each within the scatter of the next).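

In this assay, placing 3,4-difluorophenyl instead of 4-methoxyphenyl on the sulfonamide nitrogen gives a 2.3-fold lower number from compound 2 to compound 3 (0.36 log units; beyond the scatter), a modest change but the first here to exceed the normal spread of repeat measurements. The earlier change on this same aromatic group, with methoxy in place of pentyl, gave only a 1.2-fold lower number from compound 1 to compound 2 (0.09 log units; within the scatter), so that pair alone could not show whether this part of the molecule affects the result, whereas compound 3 shows that the group on this nitrogen can shift it. The swap exchanges one oxygen for two fluorine atoms and removes one hydrogen-bond acceptor, but no measurement here explains why the number fell, so those differences remain a description rather than an explanation.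

The compounds shown leave open whether both fluorine atoms are needed or whether a single one, as in 4-fluorophenyl, would produce a similar step. They also leave open how far the trend extends, for example to 3,4-dichlorophenyl, to a ring bearing a nitrile or a carboxylic acid, or to a non-aromatic group such as cyclohexyl.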